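The source may hold more compounds than are shown below. What is called first, only, known or untested is meant among the compounds shown, and "the series" means these compounds.

Of the compounds shown here, two have been measured in a functional assay on KB cells (Homo sapiens) for cytotoxicity, read by MTT assay, with a stated time of 72 h; a lower number here means a stronger inhibitor, a higher number a weaker inhibitor. Compound 1, `COc1cc2ncnc(NNC(=S)NC(=O)c3ccc(F)cc3)c2cc1OC`, gives 4530 nM in this assay. Compound 2, `O=C(NC(=S)NNc1ncnc2ccccc12)c1cccc(Cl)c1`, which carries a different core and a chloro group on its benzoyl ring, gives 4740 nM in this assay. Within the data shown here, compound 1 thus stands at one of only two numbers, and the gap between it and compound 2 is small enough to fall within the scatter of repeated measurements, so neither can be said to be stronger than the other.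

The next compound to consider is compound 3, `COc1cc2ncnc(NNC(=S)NC(=O)c3ccc(Cl)cc3)c2cc1OC`, which keeps the core of compound 1 and changes only one atom on the benzoyl ring: chloro in place of fluoro on an aromatic carbon.

Among the measured compounds shown here, no measured pair shows what this exchange does here, so any expectation rests on the two numbers above and on the fact that both halogen-bearing compounds land in the same range. The step from compound 1 to compound 3 in this assay is expected to be small, a 1.1-fold lower number from compound 1 to compound 3 (0.05 log units; within the scatter), most likely not beyond the scatter in either direction. Compound 3 is accordingly estimated at 4000 nM in this assay, with a plausible span from 1500 nM to 10000 nM.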

Compound 3, half-maximal inhibitory concentration: 4590 nM
The estimate for compound 3 lay 1.1-fold (0.06 log units) below the measured number; the range from low to high includes it.
By their numbers in this assay, from the lowest: compounds 1, 3 and 2 (each within the scatter of the next).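

Among these compounds, the exchange of 4-fluorophenyl for 4-chlorophenyl on the shared core gives a 1.0-fold higher number from compound 1 to compound 3 (0.01 log units; within the scatter) in this assay, and this is the first direct reading of a single change at this place, on an aromatic carbon para to a large group. Compounds 1 and 2 differ in more than one place and could not isolate any one change, whereas this pair shows that this assay does not tell fluoro and chloro apart here, so at this position either halogen serves equally well in this measurement. No measurement is available that would explain this result.

From the compounds shown here alone, it remains open whether a group of a different kind at this place, such as an amine, a carboxylic acid or a longer chain, or simply a hydrogen in place of the halogen, would shift the number beyond the scatter. Compound 2 also differs from compound 3 in more than one place, so what the core and the position of the chloro group each contribute remains unresolved.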